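The source may report more compounds than this note shows. Statements on the series, on what has been measured and on what is new or still open speak of the compounds shown alone.

Measured so far in an ADME assay on microsomes from liver (Mus musculus) for metabolic stability, read by LC-MS, with a stated time of 10 min; on this read-out higher numbers stand for a more stable compound and lower numbers for a less stable compound:
- compound 1 `c1cnc2c(c1)CCC[C@@H]2N(CC1CC1)C[C@H]1Cc2c(cccc2N2CCNCC2)CN1`: 88.3%
- compound 2 `CN(C[C@@H]1Cc2c(cccc2N2CCNCC2)CN1)[C@H]1CCCc2cccnc21`: 54.6%
- compound 3 `CN(C[C@H]1Cc2c(cccc2N2CCN(C3CC3)CC2)CN1)[C@H]1CCCc2cccnc21`: 7%

Compound 3 stands lowest of the three, and its gaps to both compound 2 and compound 1 lie beyond the usual scatter. With so little of the compound left after the incubation, it is the least stable of this small set.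

The next compound, compound 4 `CN(C[C@H]1Cc2c(cccc2N2CCN3CCC[C@@H]3C2)CN1)[C@H]1CCCc2cccnc21`, keeps the same atoms but joins them differently: a group of 9 heavy atoms (7 carbon, 2 nitrogen; one five-membered non-aromatic ring with 1 hetero atom, one six-membered non-aromatic ring with 2 hetero atoms) in place of a group of 9 heavy atoms (7 carbon, 2 nitrogen; one three-membered non-aromatic ring of carbon only, one six-membered non-aromatic ring with 2 hetero atoms), on an aromatic carbon. The cyclopropyl ring is gone, and a five-membered ring now shares the six-membered ring with two hetero atoms.

Going by the values given here, no measured pair here differs in one place only, so the data give no direct guide to this swap. Compound 3, at 7%, has little room left to fall, so a rise is more likely than a drop. The expected change is a number 18 percentage points higher from compound 3 to compound 4 (beyond the scatter), an estimated upward move with wide uncertainty. For compound 4 the estimated value in this assay is 25%, with an expected range from 6% to 58%.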

Compound 4, percent of the compound remaining: 36.7%
Beside the measured number, compound 4's estimate is 11.7 percentage points below it, within the range that was stated.
By their numbers in this assay, from the lowest: compound 3; then compound 4; then compound 2; then compound 1.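

At this position, on an aromatic carbon of a six-membered aromatic ring of carbon only, joining the same atoms differently is enough to move the result in this assay, giving a number 29.7 percentage points higher from compound 3 to compound 4 (beyond the scatter). The two groups have the same heavy atoms and the same counts of hydrogen-bond donors and acceptors, so those counts alone do not predict the read-out here; the three-membered ring of 4-cyclopropylpiperazin-1-yl is replaced by a five-membered ring with 1 hetero atom. Nothing available explains this step.

On these data alone, it remains open whether the opposite arrangement at the new group's defined stereocentre would give a similar result. As far as these compounds go, how a morpholine ring at this position would compare with either group also remains unknown.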